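The compounds below may be only part of what the source reports. "The series", "measured", "known", "first", "only" and "open" are said of these compounds alone.

Among the measured compounds shown here, in a functional assay on SGC-7901 cells (Homo sapiens) for antiproliferative activity, read by sulforhodamine B assay, with a stated time of 72 h (a higher number here means a weaker inhibitor, a lower number a stronger inhibitor), compound 1 (`NC(=S)N/N=C/c1ccc2ccccc2n1`) gives 32700 nM and compound 2 (`S=C(N/N=C/c1ccc2ccccc2n1)Nc1cccc(Cl)c1`) gives 61300 nM in the same test, so compound 2 stands within the scatter of compound 1, the only other compound measured so far. The next compound, compound 3 (`S=C(N/N=C/c1ccc2ccccc2n1)Nc1ccccc1`), differs from compound 2 in one place (hydrogen in place of chloro on an aromatic carbon): hydrogen in place of chloro on an aromatic carbon, which turns the 3-chlorophenyl into a phenyl. For the measured compounds named here, one measured step bears on this, the placing of a 3-chlorophenyl on the amide-type nitrogen of compound 1 (a 1.9-fold higher number from compound 1 to compound 2 (0.27 log units; within the scatter)). That whole group moved the number only within the scatter, so taking away its chloro is expected to give no step beyond the scatter in this assay either. The expected change is a 1.4-fold lower number from compound 2 to compound 3 (0.13 log units; within the scatter) at the middle of the estimate. Compound 3 is expected near 45000 nM within an estimated range of 18000 nM to 100000 nM for repeated measurements.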

Compound 3, half-maximal inhibitory concentration: 26500 nM
For compound 3 the middle estimate is 1.7-fold (0.23 log units) above the measured one; the range from low to high includes it.
By their numbers in this assay, from the lowest: compounds 3, 1 and 2 (each within the scatter of the next, the first and the last beyond it).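

Compound 3 separates the phenyl ring from its chloro, which compound 2 alone could not do. In this assay, removing the chloro gives a 2.3-fold lower number from compound 2 to compound 3 (0.36 log units; beyond the scatter) and so counts as a modest change, while the bare phenyl on the amide-type nitrogen gives a 1.2-fold lower number from compound 1 to compound 3 (0.09 log units; within the scatter) and so shows that this nitrogen carries the ring without a shift beyond the scatter. Nothing available here explains the effect of the chloro.

On these data alone, whether this shift is special to chloro remains open, and a methoxy group, an amine or a carboxylic acid at the same place on the phenyl would help to settle it. A longer chain such as butyl on the nitrogen would show whether the tolerance seen with phenyl extends beyond an aromatic ring.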